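Swapping chloro for hydroxy on a chain beside a pyrimidinone

The source may report more compounds than this note shows. Statements on the series, on what has been measured and on what is new or still open speak of the compounds shown alone.

Compound 1, `Nc1ccn(C/C=C\CCl)c(=O)n1`, carries a chloro group on a short chain with a double bond. In a functional assay on L1210 cells (Mus musculus) for inhibition (on this read-out lower numbers stand for stronger inhibition and higher numbers for weaker inhibition), compound 1 gives 10000 nM. Compound 2, `Nc1ccn(C/C=C\CO)c(=O)n1`, is the same molecule except for (hydroxy in place of chloro on a saturated chain carbon bound to a double-bonded chain carbon). For compound 2 the result is not a number but a limit of the assay, > 1000000 nM. The step from the first to the second is therefore an at least 100-fold higher number from compound 1 to compound 2 (2.00 log units; beyond the scatter), and its size is bounded only by the limit of > 1000000 nM in this assay, at which 1 of the 3 values shown sits.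

Compound 3, `Cc1cn(CC#CCCl)c(=O)[nH]c1=O`, has a different core and a chain with a triple bond; how its core differs from that of compound 1 is not broken down here. In this assay compound 3 gives 140000 nM, a weaker result than compound 1.

Compound 4, `Cc1cn(CC#CCO)c(=O)[nH]c1=O`, has not yet been measured. It differs from compound 3 by hydroxy in place of chloro on a saturated chain carbon bound to a triple-bonded carbon. Among the compounds with values here, this is the same kind of change as the one from compound 1 to compound 2, though the place is not identical: there the hydroxy sits on a saturated chain carbon bound to a double-bonded chain carbon, here on a saturated chain carbon bound to a triple-bonded carbon.

Because the earlier step was an at least 100-fold higher number from compound 1 to compound 2 (2.00 log units; beyond the scatter), a step of a 21-fold higher number from compound 3 to compound 4 (1.33 log units; beyond the scatter) is expected here as well. Since compound 3 already starts from a weak value, compound 4 is expected to give about 3000000 nM, most likely reported only as a limit, with a plausible range from 500000 nM to 20000000 nM.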

Compound 4, half-maximal inhibitory concentration: > 500000 nM
Compound 4 ended at the assay's limit; the forecaster's own chance of this, stated with the estimate: 80%; the middle value lies beyond the limit too.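

Hydroxy in place of chloro gives a weaker result in this assay on both cores shown, with an at least 3.5-fold higher number from compound 3 to compound 4 (0.55 log units; beyond the scatter), in the same direction as an at least 100-fold higher number from compound 1 to compound 2 (2.00 log units; beyond the scatter). For compound 4 the result is a limit of the assay and not a number: > 500000 nM. The direction of the change therefore carries over from the core of compound 1 to the core of compound 3 in these two pairs, but the size of the change cannot be compared, because each step rests on a limit: the same change on two cores in this assay, an at least 100-fold higher number (2.00 log units; beyond the scatter) from compound 1 to compound 2 and an at least 3.5-fold higher number (0.55 log units; beyond the scatter) from compound 3 to compound 4; the limit leaves it open whether they differ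

The two pairs differ in both the core and the chain, with a double bond in one and a triple bond in the other, so the compounds shown leave open which of these might matter for the size of the loss, and how weak compound 2 and compound 4 really are. They also leave open what an amine, a methoxy group or a bromo group would give in place of chloro, and whether the same change would hold on a longer chain.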